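Pyrazole to imidazole swap in the methylcarbamoyl series

A few compounds are considered here, and "the series" means these few. Any claim that something is new, unique, unknown or untested is made for them only; others in the source may bear on it.

In an ADME assay on microsomes from liver (Homo sapiens) for metabolic stability, read by LC-MS, using NADPH, with stated times of 5 min and 30 min, tested at 1 uM (on this read-out lower numbers stand for slow clearance and higher numbers for fast clearance), compound 1 `Cn1cc(-c2cnc(NCc3c(F)ccc4c3CCO4)c3cn[nH]c(=O)c23)cn1` gives 21 mL.min-1.g-1 and compound 2 `CN(C)C(=O)c1cc(-c2cnc(NCc3c(F)ccc4c3CCO4)c3cn[nH]c(=O)c23)n(C)n1` gives 21 mL.min-1.g-1. The comparison of these two shows no change at the digits printed from compound 1 to compound 2 (within the scatter).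

Compound 3 `CNC(=O)c1cc(-c2cnc(NCc3c(F)ccc4c3CCO4)c3cn[nH]c(=O)c23)n(C)n1` reads < 3 mL.min-1.g-1, which is a limit of the assay and not a number. The steps leading to it are an at least 7.0-fold lower number from compound 1 to compound 3 (0.84 log units; beyond the scatter) and an at least 7.0-fold lower number from compound 2 to compound 3 (0.84 log units; beyond the scatter), the second being hydrogen in place of methyl on an amide-type nitrogen.

Compound 4 `CNC(=O)c1ncc(-c2cnc(NCc3c(F)ccc4c3CCO4)c3cn[nH]c(=O)c23)n1C` has the same atoms as compound 3, joined differently: 1-methyl-2-(methylcarbamoyl)-1H-imidazol-5-yl in place of 1-methyl-3-(methylcarbamoyl)-1H-pyrazol-5-yl on an aromatic carbon. For the measured compounds named here, no measured step alters the five-membered ring while keeping the methylcarbamoyl group, so the size of this change is not directly known. The step of an at least 7.0-fold lower number from compound 2 to compound 3 (0.84 log units; beyond the scatter) shows that a single small edit in this part of the series can carry the read-out beyond the scatter, so the low reading need not survive the swap. A modest step towards higher numbers is therefore expected in this assay.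

The expected result is an at least 2.0-fold higher number from compound 3 to compound 4 (0.30 log units; that floor lies within the scatter).

For compound 4 the estimate is 6 mL.min-1.g-1, with an expected range of 3 mL.min-1.g-1 to 16 mL.min-1.g-1.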

Compound 4, intrinsic clearance in microsomes in the Homo sapiens assay: 24 mL.min-1.g-1
For compound 4 the middle estimate is 4.0-fold (0.60 log units) below the measured one, and the stated range ends below it.
By their numbers in the Homo sapiens assay, from the lowest: compounds 1, 2 and 4 (each within the scatter of the next). At a limit, below all of these: compound 3.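

In the Homo sapiens assay, rearranging the ring atoms alone, with the methylcarbamoyl group kept, gives an at least 8.0-fold higher number from compound 3 to compound 4 (0.90 log units; beyond the scatter); the lower end of this step is a limit of the assay and not a number. Compound 4 then reads level with the other two compounds, with a 1.1-fold higher number from compound 2 to compound 4 (0.06 log units; within the scatter) and a 1.1-fold higher number from compound 1 to compound 4 (0.06 log units; within the scatter), so among these four compounds the low reading belongs to compound 3 and does not follow the methylcarbamoyl group as such. In a physicochemical assay for lipophilicity, using the shake flask method, in phosphate buffer, measured as octanol-water partition, with a stated time of 30 min, at pH 7.4 (a higher number here means a more lipophilic compound, a lower number a more polar compound), compound 3 gives 2.1 and compound 4 gives 2.5. The same rearrangement also shifts the read-out in the physicochemical assay: the measured distribution coefficient of compound 3, 2.1, and of compound 4, 2.5, a number 0.40 log units higher (beyond the scatter)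

As far as these compounds go, whether this shift in distribution coefficient is linked to the change in clearance stays open, since a single pair cannot separate the two. Also open, from the compounds shown here alone, is how clearance responds on either ring when a carboxylic acid or a primary amide stands in place of the methylcarbamoyl group.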